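Chloro for nitro in an anticonvulsant imine series

The source may report more compounds than this note shows. Statements on the series, on what has been measured and on what is new or still open speak of the compounds shown alone.

The study measured three compounds in a functional assay on the whole organism (strain Swiss albino) with Mus musculus as the target, in the maximal electroshock model, with a stated time of 4 h; a higher number here means that more compound is needed for the effect, a lower number that less compound is needed. Compound 1 `COc1cc(/C=N/Cc2cccnc2)ccc1O` gives 30 mg/kg, and compound 3 `C/C(=N\Cc1cccnc1)c1cccc(N)c1` gives 30 mg/kg. Compound 2 `O=[N+]([O-])c1ccc(/C=N/Cc2cccnc2)cc1` gives 100 mg/kg, the highest number of the three; its nearest neighbour is compound 1, and the gap to compound 1 and to compound 3 lies beyond the usual scatter in both cases, so compound 2 needs more material than either for the same effect in this assay.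

Compound 4 `Clc1ccc(/C=N/Cc2cccnc2)cc1` has not yet been measured. It differs from compound 2 in one place: chloro in place of nitro on an aromatic carbon. Among the compounds with values here, no measured pair in the set shows this exact change, so the expectation rests on the spread of the three numbers alone. Since compound 2 stands at the high end of the set while compound 1 and compound 3 sit together at the lower end, compound 4 is expected to move toward those two, and the step of a 3.3-fold lower number from compound 2 to compound 4 (0.52 log units; beyond the scatter) is estimated as a moderate fall in the number, beyond the scatter. Compound 4 is therefore estimated at 30 mg/kg, with a range from 10 mg/kg to 100 mg/kg.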

Compound 4, minimum effective dose: 100 mg/kg
For compound 4 the middle estimate is 3.3-fold (0.52 log units) below the measured one; the measured number falls inside the stated range.
By their numbers in this assay, from the lowest: compounds 1 and 3 (each within the scatter of the next); then compounds 2 and 4 (each within the scatter of the next).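

Within the data shown here, replacing nitro with chloro on the aromatic carbon para to a group of 9 heavy atoms gives, in this assay, no change at the digits printed from compound 2 to compound 4 (within the scatter), the first direct reading of a single change in this set. At this position, the three heavy atoms and two hydrogen-bond acceptors of nitro give way to a single chlorine with no acceptors, and the number does not move beyond the scatter, so in this pair the high number does not depend on nitro specifically. Nothing measured here bears on why the two groups read alike.

On these data alone, it remains open whether a carboxylic acid or a trifluoromethyl group on this same carbon would shift the number. This single pair also cannot show whether any substituent at this position can lower it.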